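Cyclopropyl for Methoxyphenyl on the Amide Nitrogen

A few compounds are considered here, and "the series" means these few. Any claim that something is new, unique, unknown or untested is made for them only; others in the source may bear on it.

Among the measured compounds shown here, compound 1 `COc1ccc(N2C(=O)COc3ccc(-c4cnc(OC)c(NS(=O)(=O)c5ccc(F)cc5)c4)cc32)cc1` is the one member of this small set with a measured number: in a functional assay on HCT-116 cells (Homo sapiens) for antiproliferative activity, read by MTT assay, with a stated time of 72 h (on this read-out lower numbers stand for stronger inhibition and higher numbers for weaker inhibition), compound 1 gives 13400 nM. Compound 2 `O=C1COc2ccc(-c3ccc(O)cc3)cc2N1` reaches only a limit of this assay, where compound 2 gives > 40000 nM. The other value shown therefore sits at the limit of > 40000 nM in this assay, at which 1 of the 2 values shown sits. Compound 1 thus stands as the sole numerical point. Compound 3 `COc1ncc(-c2ccc3c(c2)N(C2CC2)C(=O)CO3)cc1NS(=O)(=O)c1ccc(F)cc1` has not yet been measured. It differs from compound 1 in one place: cyclopropyl in place of 4-methoxyphenyl on an amide-type nitrogen in a ring. For the measured compounds named here, no pair of measured compounds differs in exactly this way, so the size of the step cannot be read from the data. In this assay the expected step is a 1.6-fold higher number from compound 1 to compound 3 (0.22 log units; within the scatter), of modest size toward weaker inhibition. Compound 3 is accordingly expected to give about 22000 nM in this assay, estimated to lie between 6000 nM and 60000 nM.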

Compound 3, half-maximal inhibitory concentration: 24300 nM
Estimate against measurement, compound 3: 1.1-fold (0.04 log units) below, within the range that was stated.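

Among the compounds shown here, exchanging the group on the amide-type nitrogen in a ring gives a 1.8-fold higher number from compound 1 to compound 3 (0.26 log units; within the scatter) in this assay, the first step that can be read at this position. Cyclopropyl, with 3 heavy atoms, thus stands in for 4-methoxyphenyl, with 8 heavy atoms and a six-membered aromatic ring, without a change that can be told from the scatter, so that aromatic ring is not needed to keep the reading at this level. Compound 2 differs from both in more than one place and stays at a limit of the assay: the limit of > 40000 nM in this assay, at which 1 of the 3 values shown sits.

Going by these compounds, how an open chain such as ethyl, or a group carrying an amine or a carboxylic acid, would read on this nitrogen remains open. Whether any group here can move the number beyond the scatter, in either direction, is also unsettled.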